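Chain-length series of acylated thiadiazole glycosides

The source may report more compounds than this note shows. Statements on the series, on what has been measured and on what is new or still open speak of the compounds shown alone.

Two compounds of the series have been run in a functional assay on SK-OV-3 cells (Homo sapiens) for cytotoxicity, read by MTT assay, with a stated time of 24 h; a lower number here means a stronger inhibitor, a higher number a weaker inhibitor. Compound 1, `CCCCCCCC(=O)Nc1nnc(S[C@@H]2O[C@H](CO)[C@H](O)[C@H](O)[C@H]2O)s1`, gives 56000 nM. Compound 2, `CCCCCCCCCCCCCC(=O)Nc1nnc(S[C@@H]2O[C@H](CO)[C@H](O)[C@H](O)[C@H]2O)s1`, gives "not active" (no number reported): it returned no number in this assay, so compound 2 stands with no measured half-maximal inhibitory concentration at all, only the note that inhibition was not reached. On the numbers shown, compound 1 is the only member with a quantified value, and it is a weak one.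

The next compound, compound 3, is `C=CCCCCCCCCC(=O)Nc1nnc(S[C@@H]2O[C@H](CO)[C@H](O)[C@H](O)[C@H]2O)s1`. It is obtained from compound 2 by the change (vinyl in place of pentyl on a saturated chain carbon, eight bonds along the chain from a carbonyl carbon). The acyl chain therefore becomes shorter than in compound 2 and ends in a double bond, yet stays longer than the chain of compound 1. Compound 2 gave no number. No step size can be computed from it. The expectation is a move back toward measurable inhibition, but of unknown extent, and a limit result remains plausible. Compound 3 is expected to give about 90000 nM, within 30000 nM to 300000 nM.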

Compound 3, half-maximal inhibitory concentration: "not active" (no number reported)
Nothing numeric was reported for compound 3; there is nothing to compare the estimate with.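

Compound 2 and compound 3 both returned no number in this assay, so no step can be read between them. The compounds shown leave open whether any acyl chain longer than that of compound 1 gives a quantified value, and whether the vinyl end of compound 3 has any bearing on this read-out. No supporting measurement bears on this result.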